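Moving the methyl on the pyridinyl ring of compound 3

This account rests on a few compounds, and the source may have more. Where it says the series, first, only, none or still open, it means among the compounds named here.

Compound 1, `O=C(c1ccccc1)N1CCn2nc(-c3ccncc3)cc2C1` — in a functional assay on HEK293 cells for negative allosteric modulation of metabotropic glutamate receptor 5 (Homo sapiens), read by calcium flux, with a stated time of 20 min (a higher number here means a weaker inhibitor, a lower number a stronger inhibitor), compound 1 gives 1290 nM
Compound 2, `O=C(c1cc(Cl)cc(Cl)c1)N1CCn2nc(-c3ccccn3)cc2C1` — compound 2 gives 270 nM
Compound 3, `Cc1cccnc1-c1cc2n(n1)CCN(C(=O)c1ccccc1)C2` — compound 3 gives > 10000 nM

Compound 3 stands at the weak end of the three: its value in this assay is a limit of the assay, not a number, and the limit of > 10000 nM in this assay, at which 1 of the 3 values shown sits, marks it as the one such limit among the three. Going by the values given here, the one measured step that reaches compound 3 is an at least 7.7-fold higher number from compound 1 to compound 3 (0.88 log units; beyond the scatter); no other pair shares the same single change with it.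

Compound 4, `Cc1cccc(-c2cc3n(n2)CCN(C(=O)c2ccccc2)C3)n1`, differs from compound 3 in 6-methylpyridin-2-yl in place of 3-methylpyridin-2-yl on an aromatic carbon. The methyl therefore stays on the same pyridin-2-yl ring and only changes place on it. Among the compounds with values here, no measured pair shows this particular move, and compound 3 itself gives only a limit, so the expected step of an at least 1.2-fold lower number from compound 3 to compound 4 (0.09 log units; that floor lies within the scatter) is uncertain. Compound 4 is expected to remain weak, estimated at 8000 nM, with a range of 1500 nM to 30000 nM in this assay, and a fair chance that it too reports only a limit.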

Compound 4, half-maximal inhibitory concentration: 568 nM
Estimate against measurement, compound 4: 14-fold (1.15 log units) above; the whole stated range lies above it.
By their numbers in this assay, from the lowest: compound 2; then compound 4; then compound 1. At a limit, above all of these: compound 3.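

The methyl's place on the pyridin-2-yl ring alone, with the same atoms joined differently, gives an at least 17-fold lower number from compound 3 to compound 4 (1.24 log units; beyond the scatter) in this assay. From the compounds shown here alone, the value of compound 3 is a limit of the assay, so the true size of that step stays unknown: the limit of > 10000 nM in this assay, at which 1 of the 4 values shown sits. A methyl on this ring is therefore not a loss in itself, and 6-methylpyridin-2-yl even compares well with the pyridin-4-yl group, with a 2.3-fold lower number from compound 1 to compound 4 (0.36 log units; beyond the scatter), whereas 3-methylpyridin-2-yl gave a step the opposite way.

Going by these compounds, it remains open how much of this gain belongs to the methyl and how much to the pyridin-2-yl ring, as a pyridin-2-yl ring carrying no methyl appears here only with the two chlorines of compound 2. Also open, on these data alone, is whether an ethyl, a methoxy or a trifluoromethyl would serve in place of the methyl of 6-methylpyridin-2-yl.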